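The source may report more compounds than this note shows. Statements on the series, on what has been measured and on what is new or still open speak of the compounds shown alone.

Of the compounds shown here, three that share one core have been tested in a functional assay on MCF7 cells (Homo sapiens) for inhibition, read by sulforhodamine B assay, with a stated time of 48 h; a higher number here means a weaker inhibitor of growth, a lower number a stronger inhibitor of growth. Compound 2 `CC1=CC[C@H](C(C)(C)NC(=S)N/N=C/c2ccccc2O)CC1` gives 2200 nM. Compound 3 `CC1=CC[C@H](C(C)(C)NC(=S)N/N=C/c2ccccc2[N+](=O)[O-])CC1` gives 1200 nM; the step of a 1.8-fold lower number from compound 2 to compound 3 (0.26 log units; within the scatter) is within the scatter, so compound 2 holds the higher of these two numbers without standing apart from compound 3. Compound 1 `CC1=CC[C@H](C(C)(C)NC(=S)N/N=C/c2ccc(O)cc2)CC1` gives > 100000 nM, which is a limit of the assay rather than a number. Among the measured compounds shown here, the step of an at least 45-fold lower number from compound 1 to compound 2 (1.65 log units; beyond the scatter) is the one large change among the measured compounds.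

Compound 4 `CC1=CC[C@H](C(C)(C)NC(=S)N/N=C/c2cccs2)CC1` is not yet measured. It differs from compound 2 by thiophen-2-yl in place of 2-hydroxyphenyl on a carbon with a double bond to nitrogen. For the measured compounds named here, two measured steps bear on this: the step of an at least 45-fold lower number from compound 1 to compound 2 (1.65 log units; beyond the scatter) shows that the hydroxy-bearing ring can swing the result strongly, while the step of a 1.8-fold lower number from compound 2 to compound 3 (0.26 log units; within the scatter) shows that exchanging the group on that ring changes little. Compound 4 drops the group and the ring type together, so a weaker inhibitor than compound 2 is expected, a step of a 3.6-fold higher number from compound 2 to compound 4 (0.56 log units; beyond the scatter). Compound 4 is estimated at 8000 nM, within 1500 nM to 60000 nM.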

Compound 4, concentration for 50% growth inhibition: 4800 nM
For compound 4 the middle estimate is 1.7-fold (0.22 log units) above the measured one; measured number inside the range.
By their numbers in this assay, from the lowest: compounds 3 and 2 (each within the scatter of the next); then compound 4. At a limit, above all of these: compound 1.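

Swapping the ring on a carbon with a double bond to nitrogen for thiophen-2-yl costs only a modest amount (a 2.2-fold higher number from compound 2 to compound 4 (0.34 log units; beyond the scatter)). Compound 3 had already kept its strength without the hydroxy group, and compound 4 adds that the six-membered ring of carbon only is not needed either: a five-membered aromatic ring with sulfur and no hydrogen-bond donor still gives a measurable inhibitor. The other new step (an at least 20-fold lower number from compound 1 to compound 4 (1.31 log units; beyond the scatter)) is large, but it starts from compound 1, whose value is a limit of the assay and not a number: the limit of > 100000 nM in this assay, at which 1 of the 4 values shown sits.

On these data alone, what a plain phenyl ring with no group on it would give at this place stays open, as does the effect of an amine or a carboxylic acid on the thiophen-2-yl ring. The compounds shown vary only this one place, so they say nothing about the rest of the shared core, and they do not tell why 4-hydroxyphenyl and 2-hydroxyphenyl part so widely.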